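This account rests on a few compounds, and the source may have more. Where it says the series, first, only, none or still open, it means among the compounds named here.

The measured compounds:

compound 1, `NC(=O)c1c(NC(=O)c2ccccc2Cl)sc2c1CCN(C(=S)Nc1ccccc1F)C2`, 12600 nM
compound 2, `NC(=O)c1c(NC(=O)c2ccccc2Cl)sc2c1CCN(C(=S)Nc1ccccc1Br)C2`, 10800 nM
compound 3, `NC(=O)c1c(NC(=O)c2ccccc2F)sc2c1CCN(C(=S)Nc1ccccc1Cl)C2`, 11100 nM

All three values come from a functional assay on MKN-74 cells (Homo sapiens) for antiproliferative activity, with a stated time of 24 h; on this read-out lower numbers stand for stronger inhibition and higher numbers for weaker inhibition. Compound 4, `NC(=O)c1c(NC(=O)c2ccccc2Br)sc2c1CCN(C(=S)Nc1ccccc1Cl)C2`, has not yet been measured in this assay.

Compound 3 and compound 1 are built from the same atoms joined differently; the difference between the two cores is not broken down here. The change from compound 3 to compound 4 is bromo in place of fluoro on an aromatic carbon, and the change from compound 1 to compound 2 is bromo in place of fluoro on an aromatic carbon. The two place descriptions read the same word for word, so the two are the same change made on two different cores. Where it has already been measured, the change gave a 1.2-fold lower number from compound 1 to compound 2 (0.07 log units; within the scatter).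

The three measured values lie close together, with compound 3 standing between compound 1 and compound 2 and all pairwise gaps within the scatter. For the measured compounds named here, because the only measured instance of this change, a 1.2-fold lower number from compound 1 to compound 2 (0.07 log units; within the scatter), stayed within the scatter, compound 4 is expected to sit close to compound 3, and the step is estimated at a 1.1-fold lower number from compound 3 to compound 4 (0.05 log units; within the scatter). On that basis compound 4 is estimated at 10000 nM in this assay, with a range from 5500 nM to 18000 nM expected to cover most repeats.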

Compound 4, half-maximal inhibitory concentration: 12900 nM
For compound 4 the middle estimate is 1.3-fold (0.11 log units) below the measured one; low and high end bracket the measured number.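

In this assay, bromo in place of fluoro on the aromatic carbon of the 2-fluorophenyl group gives a 1.2-fold higher number from compound 3 to compound 4 (0.07 log units; within the scatter). Set beside the earlier case, the two steps point in opposite directions on paper, yet they cannot be told apart, so the change reads the same on both cores: the same change on two cores in this assay, a 1.2-fold lower number (0.07 log units; within the scatter) from compound 1 to compound 2 and a 1.2-fold higher number (0.07 log units; within the scatter) from compound 3 to compound 4, 1.4-fold (0.13 log units) apart, within the scatter of two such steps. This shows that, for these two pairs, swapping fluoro for bromo left the number within the scatter on either core, but it does not show that the opposite signs mean anything, that the two halogens are equivalent in general, or that the same would hold on a core outside these four compounds.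

The compounds shown carry only fluoro, chloro and bromo on their two aromatic rings, and all four values lie in one narrow band, so the series gives no case in which a change at these places moves the number beyond the scatter. From the compounds shown here alone, whether a methoxy group, an amine or a carboxylic acid in the place of the halogen would shift the number in this assay stays open, and so does whether the bromo for fluoro change would stay this small beside such groups.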